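A few compounds are considered here, and "the series" means these few. Any claim that something is new, unique, unknown or untested is made for them only; others in the source may bear on it.

Working notes on the series, measured in a functional assay on EC9706 cells (Homo sapiens) for antiproliferative activity, read by MTT assay, with a stated time of 48 h; a higher number here means a weaker inhibitor, a lower number a stronger inhibitor
compound 1 `CCCCCCCCCn1cc(COC[C@@H]2OC[C@H](N)[C@@H]2O)nn1` 20100 nM
compound 2 `CCCCCCCCCCn1cc(COC[C@@H]2OC[C@H](N)[C@@H]2O)nn1` 15600 nM
compound 3 `CCCCCCCCCn1cc(COC[C@@H]2OC[C@H](N)[C@H]2O)nn1` > 128000 nM

As far as these compounds go, for compound 3 there is no number, only the limit > 128000 nM, so its true position is unknown. The series holds one such case (the limit of > 128000 nM in this assay, at which 1 of the 3 values shown sits).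

Compound 4 `CCCCCCCCCCCCCCCCn1cc(COC[C@@H]2OC[C@H](N)[C@H]2O)nn1` keeps the configuration of compound 3 as drawn and extends its chain (heptyl in place of hydrogen on a saturated chain carbon, nine bonds along the chain from an aromatic nitrogen), with heptyl in place of hydrogen on a saturated chain carbon, nine bonds along the chain from an aromatic nitrogen.

Among the measured compounds shown here, two measured steps bear on this. The closest is the same kind of change at the same place, made on the other configuration, and it gives a 1.3-fold lower number from compound 1 to compound 2 (0.11 log units; within the scatter). That step is small, and heptyl is a far larger addition than methyl, so it can only be stretched with caution. The other step gives an at least 6.3-fold higher number from compound 1 to compound 3 (0.80 log units; beyond the scatter), where (the fact that compounds 1 and 3 differ only in the configuration as drawn). Compound 4 therefore starts from the poor side of that gap.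

A modest move toward a lower number is expected in this assay, and a result that again reaches the limit remains quite possible. The expected size of the change is an at least 2.0-fold lower number from compound 3 to compound 4 (0.30 log units; that floor lies within the scatter). For compound 4 the estimated value is 64000 nM, with an expected range from 15000 nM to 200000 nM.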

Compound 4, half-maximal inhibitory concentration: 6310 nM
For compound 4 the middle estimate is 10-fold (1.01 log units) above the measured one; the whole stated range lies above it.
By their numbers in this assay, from the lowest: compound 4; then compounds 2 and 1 (each within the scatter of the next). At a limit, above all of these: compound 3.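

In this assay heptyl in place of hydrogen on a saturated chain carbon, nine bonds along the chain from an aromatic nitrogen, gives an at least 20-fold lower number from compound 3 to compound 4 (1.30 log units; beyond the scatter) and shows that this position can carry a large change in the read-out. Methyl at the same place, on the other configuration, gave a 1.3-fold lower number from compound 1 to compound 2 (0.11 log units; within the scatter) and so showed no change that could be told from the scatter, while the heptyl step lies beyond it; the two steps differ in both group and configuration, so neither factor can be singled out. As far as these compounds go, compound 3 has only the limit > 128000 nM and no number, so the true size of the heptyl step remains unknown and only its floor is printed.

Still open, from the compounds shown here alone, is whether the configuration gap, an at least 6.3-fold higher number from compound 1 to compound 3 (0.80 log units; beyond the scatter), persists with the chain of compound 4, and whether heptyl gives a step of similar size on the configuration of compound 1. Also open, going by these compounds, is how the read-out responds to a longer chain, or to a chain of this kind ending in a carboxylic acid or an amine, at the same position.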